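The source may report more compounds than this note shows. Statements on the series, on what has been measured and on what is new or still open speak of the compounds shown alone.

Working notes on the series, read in an assay on HEK293 cells for agonist activity at Toll-like receptor 8 (Homo sapiens), read by spectrophotometry; a lower number here means that less compound is needed, a higher number that more compound is needed for the effect.

Of the compounds shown here, two have numbers so far. Compound 1 `CCCCNc1nc(N)nc(C)c1CCCN1C(=O)c2ccccc2C1=O` gives 453 nM in this assay. Compound 2 `CCCCNc1nc(N)nc(C)c1CCCc1ccccc1` gives 749 nM in this assay, the highest of the two numbers; its nearest neighbour is compound 1, and the gap between the two falls within the scatter, so the pair shows no order, only that both sit in the same region. Among the measured compounds shown here, the two differ at the end of the saturated chain and in nothing else, yet no step between them is counted here, so nothing further is read from the pair.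

Compound 3 `CCCCNc1nc(N)nc(C)c1CCCN1CCCCCC1` is the next compound, not yet measured. Against compound 2 the change is azepan-1-yl in place of phenyl on a saturated chain carbon, three bonds along the chain from an aromatic carbon. For the measured compounds named here, no measured step bears on this change, and the only comparison available, compound 1 against compound 2, stays within the scatter. Expected is a step from compound 2 to compound 3 of a 1.2-fold lower number from compound 2 to compound 3 (0.10 log units; within the scatter), with no direction beyond the scatter. Compound 3 is estimated at 600 nM in this assay, within a range from 200 nM to 2000 nM.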

Compound 3, half-maximal effective concentration: 178 nM
Compound 3: middle estimate off by 3.4-fold (0.53 log units), on the high side; measured number outside the range, below it.
By their numbers in this assay, from the lowest: compound 3; then compounds 1 and 2 (each within the scatter of the next).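

In this assay the end of the saturated chain turns out to be a place where the number can shift, something the pair of compound 1 and compound 2 could not show while it stayed within the scatter: azepan-1-yl in place of phenyl gives a 4.2-fold lower number from compound 2 to compound 3 (0.62 log units; beyond the scatter) here. The change is not a single feature, since a six-membered aromatic ring of carbon only gives way to a seven-membered non-aromatic ring with 1 hetero atom, and the entering group brings 1 hydrogen-bond acceptor where the leaving group has none, so this one step cannot separate these differences. No evidence available here accounts for the size of the step.

Still open, from the compounds shown here alone, is which of these differences carries the step, and piperidin-1-yl or cyclohexyl on the same saturated chain carbon would bear on ring size and on the ring nitrogen. Also open, going by these compounds, is whether a ring is needed at all at this position, a question that an open-chain dimethylamino or diethylamino group would address.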